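Exchanging fluoro for chloro on the aryl ring of compound 3

The compounds below may be only part of what the source reports. "The series", "measured", "known", "first", "only" and "open" are said of these compounds alone.

Compound 3 `O=C(NC(=S)Nc1ccc(F)cc1)c1cn(-c2ccccc2)nc1-c1ccc(F)cc1` in a functional assay on MCF7 cells (Homo sapiens) for inhibition, read by CCK-8 assay, with a stated time of 48 h (a lower number here means a stronger inhibitor, a higher number a weaker inhibitor), gives 5610 nM; compound 2 `O=C(NC(=S)Nc1ccc(Cl)cc1)c1cn(-c2ccccc2)nc1-c1ccc(Cl)cc1` gives 5360 nM, and compound 1 `COc1ccc(-c2nn(-c3ccccc3)cc2C(=O)NC(=S)Nc2ccc(F)cc2)cc1` gives 4990 nM, so the three sit within the scatter of one another. Compound 4 `O=C(NC(=S)Nc1ccc(F)cc1)c1cn(-c2ccccc2)nc1-c1ccc(Cl)cc1` differs from compound 3 by chloro in place of fluoro on an aromatic carbon. Within the data shown here, no measured step makes exactly this exchange. The nearest guide is a 1.1-fold higher number from compound 1 to compound 3 (0.05 log units; within the scatter), a change at the same place that stayed within the scatter, and compound 2, carrying chloro on both aryl rings, shows a number close to that of compound 3. He therefore expects a 1.1-fold lower number from compound 3 to compound 4 (0.02 log units; within the scatter), nothing beyond the scatter, and estimates compound 4 at 5300 nM, most likely between 3000 nM and 9500 nM.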

Compound 4, half-maximal inhibitory concentration: 5990 nM
Estimate against measurement, compound 4: 1.1-fold (0.05 log units) below; low and high end bracket the measured number.
By their numbers in this assay, from the lowest: compounds 1, 2, 3 and 4 (each within the scatter of the next).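

In this assay, the exchange of 4-fluorophenyl for 4-chlorophenyl gives a 1.1-fold higher number from compound 3 to compound 4 (0.03 log units; within the scatter), and chloro in place of methoxy at this position gives a 1.2-fold higher number from compound 1 to compound 4 (0.08 log units; within the scatter), so fluoro, chloro and methoxy on this ring cannot be told apart here. The first exchange made at the other aryl ring, fluoro in place of chloro, gives a 1.1-fold higher number from compound 2 to compound 4 (0.05 log units; within the scatter), which also stays within the scatter. Nothing available explains this flat response. From the compounds shown here alone, whether an amine or a carboxylic acid at this position would move the number beyond the scatter remains open.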